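The compounds below may be only part of what the source reports. "The series", "measured", "known", "first", "only" and "open" are said of these compounds alone.

Measured compounds:
- compound 1 `CC1=CC[C@H](C(C)(C)N=C=S)CC1` — in a functional assay on K562 cells (Homo sapiens) for inhibition, read by sulforhodamine B assay, with a stated time of 48 h (on this read-out lower numbers stand for stronger inhibition of growth and higher numbers for weaker inhibition of growth), compound 1 reaches only the limit > 100000 nM.
- compound 2 `CC1=CC[C@H](C(C)(C)NC(=S)N/N=C/c2ccccc2)CC1` — in this assay compound 2 gives 47600 nM.
- compound 3 `COc1ccc(/C=N/NC(=S)NC(C)(C)[C@H]2CC=C(C)CC2)cc1` — in this assay compound 3 gives 30700 nM.

Compound 1, the bare isothiocyanate, gives no number in this assay, only a limit (the limit of > 100000 nM in this assay, at which 1 of the 3 values shown sits). The two thiosemicarbazones, compound 2 and compound 3, give numbers that sit within the scatter of each other: the step of a 1.6-fold lower number from compound 2 to compound 3 (0.19 log units; within the scatter) is too small to count as a change.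

The next compound, compound 4 `CC1=CC[C@H](C(C)(C)NC(=S)N/N=C/c2ccccc2O)CC1`, differs from compound 3 by 2-hydroxyphenyl in place of 4-methoxyphenyl on a carbon with a double bond to nitrogen. Within the data shown here, the only measured step on this aryl ring, a 1.6-fold lower number from compound 2 to compound 3 (0.19 log units; within the scatter), moved the number within the scatter, so the measured series gives no sign that a substituent change on this ring shifts the read-out of this assay in either direction. Among the measured compounds shown here, no measured step covers a hydroxyl on this ring, so the expectation for compound 4 rests on that single within-scatter step alone.

For compound 4 the expected step of a 1.1-fold higher number from compound 3 to compound 4 (0.06 log units; within the scatter) is therefore no change beyond the scatter. Compound 4 is estimated at 35000 nM in this assay, with a range from 12000 nM to 100000 nM.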

Compound 4, concentration for total growth inhibition: > 100000 nM
Compound 4 ended at the assay's limit; the forecaster's own chance of this, stated with the estimate: 15%; middle value at least 2.8-fold (0.45 log units) away from the limit.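

On the aryl ring held by the carbon with a double bond to nitrogen, the substituent now makes a difference in this assay: adding a hydroxy group to this ring gives a step beyond the scatter (an at least 2.1-fold higher number from compound 2 to compound 4 (0.32 log units; beyond the scatter)), while the methoxy step stayed within it (a 1.6-fold lower number from compound 2 to compound 3 (0.19 log units; within the scatter)). The exchange of 4-methoxyphenyl for 2-hydroxyphenyl also goes beyond the scatter (an at least 3.2-fold higher number from compound 3 to compound 4 (0.51 log units; beyond the scatter)), so this ring is not indifferent to change, and of the substituents shown only the hydroxy group moves the read-out towards weaker inhibition of growth. The value of compound 4 (> 100000 nM) is a limit of the assay and not a number, and compound 4 shares it with compound 1: the limit of > 100000 nM in this assay, at which 2 of the 4 values shown sit.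

Open, going by these compounds, is whether the hydroxy group itself or its place in 2-hydroxyphenyl drives these steps, and how far past the limit compound 4 lies. Also open, on these data alone, is whether an amine or a carboxylic acid on this ring would read like the hydroxy group or like the methoxy group.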